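The source may report more compounds than this note shows. Statements on the series, on what has been measured and on what is new or still open speak of the compounds shown alone.

Working notes on the series. Among the compounds with values here, compound 1 `O=C(Nc1cc(Sc2ncn[nH]2)c(O)c2ccccc12)c1cccc([N+](=O)[O-])c1` is the only member with a measured number: in a functional assay on HCT-116 cells (Homo sapiens) for antiproliferative activity, read by MTT assay, with a stated time of 48 h (on this read-out lower numbers stand for stronger inhibition and higher numbers for weaker inhibition), compound 1 gives 70200 nM. Compound 2 `O=C(Nc1cc(Sc2ncnc3nc[nH]c23)c(O)c2ccccc12)c1ccc(Cl)cc1` shares the core but carries a different heteroaryl sulfide and a different benzamide; in this assay compound 2 returns no number, only a limit, > 100000 nM. That value is the limit of > 100000 nM in this assay, at which 1 of the 2 values shown sits, so the set so far holds one weak number and one entry that is a limit rather than a number. Compound 3 `COc1ccc(C(=O)Nc2cc(Sc3ncn[nH]3)c(O)c3ccccc23)cc1` is still to be measured. It differs from compound 1 in one place: 4-methoxyphenyl in place of 3-nitrophenyl on a carbonyl carbon. Within the data shown here, no measured pair in the set differs in just this way, so the step cannot be read from precedent and the nitro and methoxy groups carry no measured evidence here. The expected step is a 1.0-fold lower number from compound 1 to compound 3 (0.00 log units; within the scatter), that is, nothing beyond the usual scatter in either direction. Compound 3 is therefore estimated at 70000 nM in this assay, with a range from 25000 nM to 200000 nM.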

Compound 3, half-maximal inhibitory concentration: > 100000 nM
Compound 3: a limit, no number (the forecaster's own chance of this, stated with the estimate: 30%); middle value at least 1.4-fold (0.15 log units) from the limit.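

On the carbonyl carbon, 4-methoxyphenyl in place of 3-nitrophenyl gives an at least 1.4-fold higher number from compound 1 to compound 3 (0.15 log units; that floor lies within the scatter); the far end of that step is a limit, so it is a floor and not a size. This position now has its first direct comparison, and the 4-methoxyphenyl amide returns no number in this assay, which leaves compound 1 as the only entry with a figure. Limits now make up most of the set: the limit of > 100000 nM in this assay, at which 2 of the 3 values shown sit.

The change swaps the group and its place on the phenyl ring together, so the compounds shown do not separate the two, nor do they show how far compound 3 lies past its limit. On these data alone, whether an amine or a carboxylic acid on this phenyl ring would return a number in this assay stays open.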